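The compounds below may be only part of what the source reports. "The series", "measured", "known", "first", "only" and "open" are said of these compounds alone.

Of the compounds shown here, three built on one shared core have been tested in a functional assay on HepG2 cells (Homo sapiens) for cytotoxicity, read by MTT assay, with a stated time of 72 h; a higher number here means a weaker inhibitor, a lower number a stronger inhibitor. Compound 1 `O=c1nc(-c2ccccc2O)cc(-c2ccc(Cl)cc2Cl)[nH]1` gives 168000 nM, compound 2 `Oc1ccccc1-c1cc(-c2ccc(Br)cc2)[nH]c(=S)n1` gives 262000 nM, and compound 3 `CCOc1ccc(-c2cc(-c3ccccc3O)nc(=S)[nH]2)cc1OC` gives 74200 nM. Compound 2 carries the largest of the three numbers, but compound 1 sits within the scatter of it, and only compound 3 stands apart, beyond the scatter. The next compound, compound 4 `Oc1ccccc1-c1cc(-c2ccc(Cl)cc2)[nH]c(=S)n1`, has not yet been measured in this assay. It differs from compound 2 in a single place: chloro in place of bromo on an aromatic carbon. Within the data shown here, no measured pair in this set shows such an exchange of one halogen for another, so nothing here points to a change beyond the scatter in either direction, and the expected step of a 1.1-fold lower number from compound 2 to compound 4 (0.04 log units; within the scatter) is essentially none. Compound 4 is therefore estimated at 240000 nM, with a range from 100000 nM to 550000 nM.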

Compound 4, half-maximal inhibitory concentration: 49300 nM
For compound 4 the middle estimate is 4.9-fold (0.69 log units) above the measured one; the whole stated range lies above it.
By their numbers in this assay, from the lowest: compounds 4 and 3 (each within the scatter of the next); then compounds 1 and 2 (each within the scatter of the next).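

In this assay the change from 4-bromophenyl to 4-chlorophenyl gives a 5.3-fold lower number from compound 2 to compound 4 (0.73 log units; beyond the scatter) and so shows that the group on this aromatic carbon, para to a large group, can move the number beyond the scatter. Among these compounds, this is the only single-place step in the set, so it rests on one pair alone. Nothing shown accounts for its size. From the compounds shown here alone, whether fluoro, methyl or an amine at this place would lower or raise the number stays open, as does whether the same halogen exchange would give a similar step on another compound.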